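Swapping methyl for trifluoromethyl on compound 3

A few compounds are considered here, and "the series" means these few. Any claim that something is new, unique, unknown or untested is made for them only; others in the source may bear on it.

compound 1 `COc1cc(OC)c(-c2coc3cc(OCC=C(C)C)ccc3c2=O)cc1OC`: 3800 nM
compound 2 `COc1cc(OC)c(-c2coc3cc(OCC(=O)c4cccc(C(F)(F)F)c4)ccc3c2=O)cc1OC`: > 10000 nM (a limit of the assay, not a number)
compound 3 `COc1cc(OC)c(-c2coc3cc(OCc4ccccc4C)ccc3c2=O)cc1OC`: 4830 nM

All three share one core and differ only in the chain on its oxygen, and all were tested in a functional assay on HUVEC cells (Homo sapiens) for antiproliferative activity, read by MTT assay, with a stated time of 24 h; on this read-out lower numbers stand for stronger inhibition and higher numbers for weaker inhibition. Compound 3 sits level with compound 1, as the step shows: a 1.3-fold higher number from compound 1 to compound 3 (0.10 log units; within the scatter). Compound 2 stands at the limit of > 10000 nM in this assay, at which 1 of the 3 values shown sits.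

Compound 4 `COc1cc(OC)c(-c2coc3cc(OCc4ccccc4C(F)(F)F)ccc3c2=O)cc1OC` changes compound 3 in one place: trifluoromethyl in place of methyl on an aromatic carbon. Trifluoromethyl takes the place of methyl on an aromatic carbon, ortho to a large group.

Within the data shown here, no measured step makes this exact swap. The nearest guide is a 1.3-fold higher number from compound 1 to compound 3 (0.10 log units; within the scatter), which shows that a large change in this chain left the number within the scatter. Compound 2 also carries trifluoromethyl, but within a (3-(trifluoromethyl)phenyl)carbonyl group, so an at least 2.6-fold higher number from compound 1 to compound 2 (0.42 log units; beyond the scatter) and an at least 2.0-fold lower number from compound 2 to compound 3 (0.31 log units; beyond the scatter) each involve more than that one group. They only warn that some changes here can raise the number. A small change is therefore expected in this assay, and the expected step is a 1.1-fold higher number from compound 3 to compound 4 (0.06 log units; within the scatter). The estimate for compound 4 is 5500 nM, with an expected range of 2500 nM to 10000 nM.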

Compound 4, half-maximal inhibitory concentration: > 10000 nM
Compound 4 ended at the assay's limit; the forecaster's own chance of this, stated with the estimate: 20%; middle value at least 1.8-fold (0.25 log units) from the limit.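

In this assay, among these compounds, this is the first step at this position that changes a single group, and the swap of methyl for trifluoromethyl on the aromatic ring moves the number beyond the scatter: an at least 2.0-fold higher number from compound 3 to compound 4 (0.31 log units; beyond the scatter). The chain on the oxygen is therefore not indifferent to what it carries: the 2-methylprop-1-en-1-yl and 2-methylphenyl chains read level with each other, yet the 2-(trifluoromethyl)phenyl chain does not, with an at least 2.6-fold higher number from compound 1 to compound 4 (0.42 log units; beyond the scatter). Compound 2 and compound 4 both rest at a limit of the assay rather than at a number, so the step between them cannot be read, and this end of the series now holds both of them: the limit of > 10000 nM in this assay, at which 2 of the 4 values shown sit.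

From the compounds shown here alone, how far compound 4 really lies past that limit stays open, so the step from compound 3 gives only a minimum size and not the full one. Also open, going by these compounds, is whether a chlorine atom or a methoxy group in place of the methyl would keep the number level with compound 3 or send it to the limit as trifluoromethyl does.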